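Methyl in Place of Methoxy on the Shared Core

A few compounds are considered here, and "the series" means these few. Any claim that something is new, unique, unknown or untested is made for them only; others in the source may bear on it.

Compound 1 `CCn1c(=O)/c(=C2\Sc3ccccc3N2C)s/c1=C\c1ccncc1Nc1ccccc1C`: 1200 nM
Compound 2 `CCn1c(=O)/c(=C2\Sc3ccc(OC)cc3N2C)s/c1=C\c1ccncc1Nc1ccccc1C`: 370 nM

In a functional assay on PC-3 cells (Homo sapiens) for inhibition (on this read-out lower numbers stand for stronger inhibition and higher numbers for weaker inhibition), compound 2 gives 370 nM, the lowest of the two numbers; its nearest neighbour is compound 1, and the step of a 3.2-fold lower number from compound 1 to compound 2 (0.51 log units; beyond the scatter) lies beyond the scatter. Compound 3 `CCn1c(=O)/c(=C2\Sc3ccc(C)cc3N2C)s/c1=C\c1ccncc1Nc1ccccc1C` differs from compound 2 by methyl in place of methoxy on an aromatic carbon. For the measured compounds named here, only one measured step bears on this change, a 3.2-fold lower number from compound 1 to compound 2 (0.51 log units; beyond the scatter), where methoxy replaced hydrogen at the same place. Methyl keeps a substituent there, so a small upward step or none beyond the scatter is expected, a 1.4-fold higher number from compound 2 to compound 3 (0.13 log units; within the scatter). Compound 3 is estimated at 500 nM, between 200 nM and 1300 nM.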

Compound 3, half-maximal inhibitory concentration: 330 nM
Compound 3: middle estimate off by 1.5-fold (0.18 log units), on the high side, within the range that was stated.
By their numbers in this assay, from the lowest: compounds 3 and 2 (each within the scatter of the next); then compound 1.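

In this assay, methyl and methoxy cannot be told apart at this aromatic carbon: a 1.1-fold lower number from compound 2 to compound 3 (0.05 log units; within the scatter) stays within the scatter. Methyl also stands clear of hydrogen, with a 3.6-fold lower number from compound 1 to compound 3 (0.56 log units; beyond the scatter), so the oxygen of methoxy is not required for a number at this level. Nothing at hand gives a cause for this result. On these data alone, whether an amine, a nitrile or a carboxylic acid on this carbon would keep the number at this level stays open. So does whether a longer chain such as ethoxy would do so.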